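The source may report more compounds than this note shows. Statements on the series, on what has been measured and on what is new or still open speak of the compounds shown alone.

This account concerns three measured compounds and one that has not yet been tested in a functional assay on CNE cells (Homo sapiens) for cytotoxicity, read by MTT assay, with a stated time of 72 h; a higher number here means a weaker inhibitor, a lower number a stronger inhibitor. Compound 1 has the structure `COCOc1cc(/C=C/C(=O)OCC(=O)Nc2ccc(Cl)cc2)ccc1OCc1ccccc1`. In this assay compound 1 gives > 200000 nM, which is a limit of the assay rather than a measured number. Compound 2, `CCOc1ccc(COc2c(OC)cc(/C=C/C(=O)OCC(=O)Nc3ccccc3)cc2OC)cc1`, is a related structure; in this assay compound 2 gives > 200000 nM, again a limit. For the measured compounds named here, compound 3, `O=C(COC(=O)/C=C/c1ccc(O)c(O)c1)Nc1ccc(Cl)cc1`, gives 89600 nM in this assay, the only finite number among the three. Compound 1 therefore stands at the limit of > 200000 nM in this assay, at which 2 of the 3 values shown sit, and there is no number that would place it against compound 3. The untested compound 4, `COCOc1cc(/C=C/C(=O)OCC(=O)NCc2ccco2)ccc1OCc1ccccc1`, differs from compound 1 in a single place: (furan-2-yl)methyl in place of 4-chlorophenyl on an amide-type nitrogen. Going by the values given here, no pair of measured compounds shows this change, so no measured step guides the expectation. This step, a number no higher from compound 1 to compound 4 (the limit leaves the size open), is expected to amount to nothing beyond the usual scatter in this assay. Compound 4 is accordingly expected to give 200000 nM, most likely again as a limit, with a range from 80000 nM to 500000 nM.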

Compound 4, half-maximal inhibitory concentration: > 200000 nM
Compound 4: no number, only a limit; the forecaster's own chance of this, stated with the estimate: 75%; the middle value lies on the limit itself.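

Compound 1 and compound 4 both sit at a limit of the assay in this assay, not at a measured number, so no step can be read between them. The compounds shown leave open whether (furan-2-yl)methyl in place of 4-chlorophenyl changes the read-out at all, and by how much.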